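From 4-methoxyphenyl to 5-methoxypyrazin-2-yl on compound 1

A few compounds are considered here, and "the series" means these few. Any claim that something is new, unique, unknown or untested is made for them only; others in the source may bear on it.

In a functional assay on PANC-1 cells (Homo sapiens), read by microscopy, crystal violet staining and transwell migration, with a stated time of 18 h, in the presence of a further agent that is not named here (on this read-out higher numbers stand for weaker inhibition and lower numbers for stronger inhibition), compound 1 `CCc1nc(-c2ccc(OC)cc2)n(-c2cccc(C(=O)NCCCCc3ccccc3)c2)n1` gives 140 nM as the lowest of three numbers. Compound 3 `COc1ccc(-c2nc(C3CC3)nn2-c2cccc(C(=O)NCCCCc3ccccc3)c2)cc1` gives 7680 nM and compound 2 `CCCCc1nc(-c2ccc(OC)cc2)n(-c2cccc(C(=O)NCCCCc3ccccc3)c2)n1` gives 16800 nM as higher numbers. Compound 4 `CCc1nc(-c2cnc(OC)cn2)n(-c2cccc(C(=O)NCCCCc3ccccc3)c2)n1` carries 5-methoxypyrazin-2-yl in place of 4-methoxyphenyl on an aromatic carbon. Among the measured compounds shown here, no measured step touches that group. The measured steps change only the ethyl group of compound 1, with a 120-fold higher number from compound 1 to compound 2 (2.08 log units; beyond the scatter) and a 55-fold higher number from compound 1 to compound 3 (1.74 log units; beyond the scatter) both large. They show that numbers can move far among these three compounds, but they give no size for this swap. Compound 1 already holds the lowest number, so a moderately higher number in this assay is expected. The expected move is a 6.4-fold higher number from compound 1 to compound 4 (0.81 log units; beyond the scatter) in this estimate. Compound 4 is estimated at 900 nM with an expected range from 150 nM to 6000 nM overall.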

Compound 4, half-maximal inhibitory concentration: 310 nM
Estimate against measurement, compound 4: 2.9-fold (0.46 log units) above; measured number inside the range.
By their numbers in this assay, from the lowest: compound 1; then compound 4; then compound 3; then compound 2.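

In this assay, among the compounds shown here, the first change to the 4-methoxyphenyl group gives a 2.2-fold higher number from compound 1 to compound 4 (0.35 log units; beyond the scatter), so a ring with 2 hetero atoms can replace the ring of carbon only at this position at a modest cost. That step is much smaller than the change to the ethyl group in a 120-fold higher number from compound 1 to compound 2 (2.08 log units; beyond the scatter), although the two steps sit at different places on the shared core. No measurement here explains the modest rise. Going by these compounds, whether a single ring nitrogen, as in 5-methoxypyridin-2-yl, would give a similar number remains open. So does the part played by the methoxy group, which an amine in its place would help to test.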